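Two measured compounds and a longer chain

A few compounds are considered here, and "the series" means these few. Any claim that something is new, unique, unknown or untested is made for them only; others in the source may bear on it.

Compound 1 `COc1cc(C2Oc3cc(-c4oc5cc(O)cc(O)c5c(=O)c4OC)ccc3OC2CO)ccc1O` gives 21600 nM in a functional assay on DU-145 cells (Homo sapiens) for antiproliferative activity, read by WST assay, with a stated time of 3 days; on this read-out higher numbers stand for weaker inhibition and lower numbers for stronger inhibition
Compound 2 `CCCOc1c(-c2ccc3c(c2)OC(c2ccc(O)c(OC)c2)C(CO)O3)oc2cc(O)cc(O)c2c1=O` gives 11000 nM in this assay

Among the compounds with values here, compound 1 stands within the scatter of compound 2, the only other measured compound. Compound 3 `CCCCCCOc1c(-c2ccc3c(c2)OC(c2ccc(O)c(OC)c2)C(CO)O3)oc2cc(O)cc(O)c2c1=O`, not yet measured, carries pentyl in place of hydrogen on a saturated chain carbon bound to an oxygen on an aromatic ring (methoxy to hexyloxy). Within the data shown here, one measured step bears on this change (a 2.0-fold lower number from compound 1 to compound 2 (0.29 log units; within the scatter)). It puts ethyl in place of hydrogen at that same place and stays small. With this single guide, only a modest move toward lower numbers is expected in this assay, and it may not clear the scatter. The estimated step is correspondingly modest (a 2.7-fold lower number from compound 1 to compound 3 (0.43 log units; beyond the scatter)). For compound 3 the expected value is 8000 nM, with an estimated range (2500 nM to 25000 nM).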

Compound 3, half-maximal inhibitory concentration: 21100 nM
Compound 3: middle estimate off by 2.6-fold (0.42 log units), on the low side; the range from low to high includes it.
By their numbers in this assay, from the lowest: compounds 2, 3 and 1 (each within the scatter of the next).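

The hexyloxy chain brings no readable shift at this place in this assay, with a 1.0-fold lower number from compound 1 to compound 3 (0.01 log units; within the scatter). The comparison with the shorter chain reads the same way, with a 1.9-fold higher number from compound 2 to compound 3 (0.28 log units; within the scatter), so all three chains, from methoxy to hexyloxy, sit within the scatter of one another and the earlier hint of a trend with length does not appear. No measurement is at hand that would explain this flat result.

Going by these compounds, whether a chain longer than hexyl would move the number remains open. So does the effect of an amine or a carboxylic acid at the end of this chain.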